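Extending the Chain on the Amide Sulfonamide Ester Pair

A few compounds are considered here, and "the series" means these few. Any claim that something is new, unique, unknown or untested is made for them only; others in the source may bear on it.

Compound 1, `CCCCCOC(=O)c1ccc(S(N)(=O)=O)cc1`, gives 2.71 in a physicochemical assay for lipophilicity; a higher number here means a more lipophilic compound, a lower number a more polar compound.
Compound 2, `CCCCCCOC(=O)c1ccc(S(N)(=O)=O)cc1`, gives 3.23 in this assay.
Compound 3, `CCCCCNC(=O)c1ccc(S(N)(=O)=O)cc1`, gives 1.54 in this assay.

Two structural moves connect these three measured compounds. Compound 3 differs from compound 1 by pentylamino in place of pentyloxy on a carbonyl carbon, and this gives a number 1.17 log units lower from compound 1 to compound 3 (beyond the scatter), the largest step in the set. Compound 2 differs from compound 1 by methyl in place of hydrogen on a saturated chain carbon, five bonds along the chain from an oxygen next to a carbonyl group, which gives a number 0.52 log units higher from compound 1 to compound 2 (beyond the scatter).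

Compound 4, `CCCCCCNC(=O)c1ccc(S(N)(=O)=O)cc1`, has not yet been measured. It differs from compound 3 by methyl in place of hydrogen on a saturated chain carbon, five bonds along the chain from an amide-type nitrogen. For the measured compounds named here, this is the same kind of change as the one from compound 1 to compound 2, but the place is not identical: there the extra carbon sits five bonds along the chain from an oxygen next to a carbonyl group, here five bonds along the chain from an amide-type nitrogen.

Going by the values given here, compound 4 is expected to show a step of a number 0.51 log units higher from compound 3 to compound 4 (beyond the scatter) in this assay, because a number 0.52 log units higher from compound 1 to compound 2 (beyond the scatter) is the only measured guide for this kind of change. Compound 4 is therefore estimated at 2.05, likely between 1.75 and 2.35.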

Compound 4, partition coefficient: 2.05
Beside the measured number, compound 4's estimate shows no gap at the digits printed, within the range that was stated.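

In this assay the added methyl on the amide chain gives a number 0.51 log units higher from compound 3 to compound 4 (beyond the scatter) and the same kind of change on the ester chain gives a number 0.52 log units higher from compound 1 to compound 2 (beyond the scatter) so, for these two cores, the change carries over at nearly the same size. This rests on just one ester pair and one amide pair, each extended at a single chain length, so it shows agreement in this case and not a rule for every core in the series. Nothing measured here explains why the two steps are so alike.

Going by these compounds, whether a longer chain, such as heptyl or octyl, would keep adding steps of this size on either core stays open. Also open, on these data alone, is whether the same change would carry over at a similar size if the chain ended in an amine or a carboxylic acid, where the two cores might no longer behave alike.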